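This account rests on a few compounds, and the source may have more. Where it says the series, first, only, none or still open, it means among the compounds named here.

In an assay on membranes from brain for binding affinity to Lysophosphatidylserine lipase ABHD12 (Mus musculus), read by fluorescence, with a stated time of 20 min (a higher number here means a weaker inhibitor, a lower number a stronger inhibitor), the three measured compounds give these numbers:

Compound 1 `S=C(Nc1cccnc1)NC1CCN(c2cc(OCc3ccccc3)ccn2)CC1`: 2800 nM
Compound 2 `S=C(Nc1cccnc1)NC1CCN(c2cc(Cl)ccn2)CC1`: 2100 nM
Compound 3 `S=C(Nc1cccnc1)NC1CCN(c2cc(OCC3CC3)ccn2)CC1`: 4700 nM

Compound 3 holds the highest of the three numbers: a 1.7-fold higher number from compound 1 to compound 3 (0.22 log units; within the scatter), and a 2.2-fold higher number from compound 2 to compound 3 (0.35 log units; beyond the scatter). Compound 4 `Fc1ccc(Oc2ccnc(N3CCC(NC(=S)Nc4cccnc4)CC3)c2)cc1` keeps the shared core and the oxygen on the aromatic ring, and differs from compound 3 by 4-fluorophenyl in place of cyclopropylmethyl on an oxygen on an aromatic ring. Among the measured compounds shown here, the step that bears most closely on this is the one from compound 1 to compound 3, which exchanged phenyl for cyclopropyl on the chain carbon bound to that oxygen: a 1.7-fold higher number from compound 1 to compound 3 (0.22 log units; within the scatter). For the measured compounds named here, the new change runs the other way, from a saturated group back to an aromatic one, though now the ring sits directly on the oxygen and carries fluorine, and no measured step covers that exactly. The expected outcome is therefore a small move toward a lower number, at most at the edge of the scatter, estimated as a 1.6-fold lower number from compound 3 to compound 4 (0.19 log units; within the scatter). For compound 4 the estimated value in this assay is 3000 nM, with a range from 1200 nM to 7500 nM.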

Compound 4, half-maximal inhibitory concentration: 1400 nM
The estimate for compound 4 lay 2.1-fold (0.33 log units) above the measured number; the range from low to high includes it.
By their numbers in this assay, from the lowest: compounds 4, 2, 1 and 3 (each within the scatter of the next, the first and the last beyond it).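

In this assay the change from cyclopropylmethyl to 4-fluorophenyl on the oxygen gives a step beyond the scatter (a 3.4-fold lower number from compound 3 to compound 4 (0.53 log units; beyond the scatter)), so compound 3 now stands apart from both compound 2 and compound 4. The other two new steps stay within the scatter (a 1.5-fold lower number from compound 2 to compound 4 (0.18 log units; within the scatter); a 2.0-fold lower number from compound 1 to compound 4 (0.30 log units; within the scatter)), so 4-fluorophenoxy cannot be told apart from chloro or benzyloxy at this aromatic carbon. No supporting evidence bears on this result.

The compounds shown leave open whether the fluorine plays any part, since no phenoxy group without it stands among them. They also leave open how an amine or a carboxylic acid at this aromatic carbon would compare.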